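The source may hold more compounds than are shown below. What is called first, only, known or untested is meant among the compounds shown, and "the series" means these compounds.

Compound 1 `CCCOC(=O)c1cccc(C(=O)Nc2cccc(-c3cc(C(=O)Nc4ccncc4F)ccc3CN)c2)c1`: 1.8 nM
Compound 2 `NCc1ccc(C(=O)Nc2ccncc2F)cc1-c1cccc(C(=O)Nc2cccc(CC(=O)O)c2)c1`: 1.5 nM
Compound 3 `CCCOC(=O)c1ccc(NC(=O)c2cccc(-c3cc(C(=O)Nc4ccncc4F)ccc3CN)c2)cc1`: < 1 nM, a limit of the assay

In an assay on cells for inhibition of Rho-associated protein kinase 2 (Homo sapiens), read by radiometric assay and 33P incorporation, in the presence of a further agent that is not named here (a higher number here means a weaker inhibitor, a lower number a stronger inhibitor), compound 1 gives the higher of the two numbers, though compound 2 lies within the scatter of it. Compound 3 reaches only the limit (the limit of < 1 nM in this assay, at which 1 of the 3 values shown sits). The unmeasured compound 4 `NCc1ccc(C(=O)Nc2ccncc2F)cc1-c1cccc(NC(=O)c2ccc(C(=O)O)cc2)c1` differs from compound 1 by 4-carboxyphenyl in place of 3-(propoxycarbonyl)phenyl on a carbonyl carbon. Going by the values given here, the one measured step that bears on this is an at least 1.5-fold lower number from compound 2 to compound 3 (0.17 log units; that floor lies within the scatter), which stays within the scatter. A carboxylic acid on that aryl is already present in compound 2, which gives 1.5 nM, so no step beyond the scatter is expected, a 1.1-fold lower number from compound 1 to compound 4 (0.02 log units; within the scatter). Compound 4 is therefore estimated at 1.7 nM, between 0.7 nM and 4 nM.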

Compound 4, half-maximal inhibitory concentration: 1 nM
Beside the measured number, compound 4's estimate is 1.7-fold (0.23 log units) above it; the range from low to high includes it.
By their numbers in this assay, from the lowest: compounds 4, 2 and 1 (each within the scatter of the next).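

In this assay, the change at this carbonyl carbon reads as a 1.8-fold lower number from compound 1 to compound 4 (0.26 log units; within the scatter). It shows that a free carboxylic acid on the 4-carboxyphenyl group and the ester of the 3-(propoxycarbonyl)phenyl group are not told apart here, so this place accepts either group on this amide. The propyl ester chain is not needed for a low number in this assay.

The change alters both the group and its place on the ring, so neither can be read alone. From the compounds shown here alone, a 3-carboxyphenyl or 4-(propoxycarbonyl)phenyl group on this carbonyl carbon would separate them, and an amine at this place remains open.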